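The compounds below may be only part of what the source reports. "The series", "measured", "known", "first", "only" and "open" are said of these compounds alone.

In a functional assay on HT-29 cells (Homo sapiens) for inhibition, read by MTT assay, with a stated time of 48 h (a higher number here means a weaker inhibitor, a lower number a stronger inhibitor), compound 1 (`COc1cc(-c2nnc(S)n2-c2ccc(N(C)C)cc2)cc(OC)c1OC`) gives > 60000 nM, which is a limit. Compound 2 (`CCSc1nnc(-c2cc(OC)c(OC)c(OC)c2)n1-c1ccc(N(C)C)cc1`) gives > 60000 nM, also a limit and not a number. Among the compounds with values here, the series so far therefore rests on (the limit of > 60000 nM in this assay, at which 2 of the 2 values shown sit). Within the data shown here, the one measured step is a step that the two limits leave unreadable from compound 1 to compound 2, so it offers no size to carry forward. Compound 3 (`COc1cc(-c2nnc(SCc3ccccc3)n2-c2ccc(N(C)C)cc2)cc(OC)c1OC`) differs from compound 2 by phenyl in place of methyl on a saturated chain carbon bound to a sulfur, turning ethylsulfanyl into benzylsulfanyl. With so little to go on, the expected step, an at least 1.3-fold lower number from compound 2 to compound 3 (0.12 log units; that floor lies within the scatter), is a loose estimate with no firm direction. For compound 3 the estimated value is 45000 nM, within an expected range of 10000 nM to 100000 nM.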

Compound 3, half-maximal inhibitory concentration: > 60000 nM
Compound 3: a limit, no number; the forecaster's own chance of this, stated with the estimate: 60%; middle value at least 1.3-fold (0.12 log units) away from the limit.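

The steps among compound 1, compound 2 and compound 3 cannot be read, as each value is a limit and not a number: the limit of > 60000 nM in this assay, at which 3 of the 3 values shown sit. The compounds shown leave open whether any group on the sulfur gives a measurable value in this assay.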